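Swapping the Benzyl Amide Group for Cyclohexyl

A few compounds are considered here, and "the series" means these few. Any claim that something is new, unique, unknown or untested is made for them only; others in the source may bear on it.

Compound 1 `COc1ccc(CNC(=O)c2cc(Oc3ccc(/C=C/c4ccccn4)cc3)ccn2)cc1`: 63600 nM
Compound 2 `O=C(Nc1ccc(Cl)cc1)c1cc(Oc2ccc(/C=C/c3ccncc3)cc2)ccn1`: 62100 nM
Compound 3 `COc1ccc(CNC(=O)c2cc(Oc3ccc(/C=C/c4ccncc4)cc3)ccn2)cc1`: 19300 nM

In a functional assay on A549 cells (Homo sapiens) for antiproliferative activity, read by CCK-8 assay, with a stated time of 48 h (on this read-out lower numbers stand for stronger inhibition and higher numbers for weaker inhibition), compound 3 gives the lowest of the three numbers. Both steps leading to it lie beyond the scatter: a 3.3-fold lower number from compound 1 to compound 3 (0.52 log units; beyond the scatter) and a 3.2-fold lower number from compound 2 to compound 3 (0.51 log units; beyond the scatter).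

Compound 4 `O=C(NC1CCCCC1)c1cc(Oc2ccc(/C=C/c3ccncc3)cc2)ccn1` has not been measured. It differs from compound 3 in one place: cyclohexyl in place of 4-methoxybenzyl on an amide-type nitrogen. Among the measured compounds shown here, the only measured step on the amide-type nitrogen is a 3.2-fold lower number from compound 2 to compound 3 (0.51 log units; beyond the scatter), which shows that the group on this nitrogen moves the number by a modest amount. Cyclohexyl has not been tried here, so the direction is uncertain; a modest rise in number, toward the other two compounds, is expected, a 2.1-fold higher number from compound 3 to compound 4 (0.32 log units; beyond the scatter). Compound 4 is therefore estimated at 40000 nM, with a range from 15000 nM to 110000 nM.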

Compound 4, half-maximal inhibitory concentration: 16800 nM
Estimate against measurement, compound 4: 2.4-fold (0.38 log units) above; the range from low to high includes it.
By their numbers in this assay, from the lowest: compounds 4 and 3 (each within the scatter of the next); then compounds 2 and 1 (each within the scatter of the next).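

In this assay, cyclohexyl on the amide-type nitrogen gives a 1.1-fold lower number from compound 3 to compound 4 (0.06 log units; within the scatter) and so holds the number reached with 4-methoxybenzyl, which shows that neither the aromatic ring nor the oxygen of that group is needed here. Among the compounds shown here, the other step is a 3.7-fold lower number from compound 2 to compound 4 (0.57 log units; beyond the scatter) and, with compound 3, leaves 4-chlorophenyl as the one group of the three with a higher number. Nothing measured here explains these results.

Going by these compounds, whether a smaller group on this nitrogen, such as methyl, or a chain ending in an amine would move the number away from that of compound 3 and compound 4 remains open. On these data alone, it is also open whether cyclohexyl would do the same with pyridin-2-yl on the chain.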